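The source may hold more compounds than are shown below. What is called first, only, known or untested is meant among the compounds shown, and "the series" means these compounds.

In an ADME assay on microsomes from liver (Homo sapiens) for metabolic stability, read by LC-MS, with a stated time of 60 min (on this read-out lower numbers stand for a less stable compound and higher numbers for a more stable compound), compound 1 (`CNc1cc(C)c(C(N)=O)cn1`) gives 95% and compound 2 (`NC(=O)c1cnc2c(c1)CCN2`) gives 100% on the same read-out, so the two values lie within the scatter of each other. Compound 3 (`Cc1c(C(N)=O)cnc2c1CCN2`) is compound 2 with methyl in place of hydrogen on an aromatic carbon, opposite the ring nitrogen (methyl in place of hydrogen on an aromatic carbon). Among the measured compounds shown here, no measured pair shows this change. Compound 1 also carries a methyl and gives 95% on this read-out, so in this assay only a small drop, within the scatter, is expected. An estimated change (a number 7 percentage points lower from compound 2 to compound 3 (within the scatter)) of this size would not separate the compounds. For compound 3 the expected value is 93% with an estimated range from 80% to 100% on this read-out.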

Compound 3, percent of the compound remaining: 85%
Compound 3: the middle estimate sits 8 percentage points above what was measured, within the range that was stated.
By their numbers in this assay, from the lowest: compounds 3, 1 and 2 (each within the scatter of the next, the first and the last beyond it).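

Methyl in place of hydrogen on an aromatic carbon, ortho to a carbamoyl group and opposite the ring nitrogen, gives a number 15 percentage points lower from compound 2 to compound 3 (beyond the scatter) in this assay, so this position is not indifferent to substitution on this read-out. Compound 1 also carries a methyl and gives 95%, but it differs from compound 3 in more than one place, so its value does not inform this step. Nothing available bears on the reason for the step.

As far as these compounds go, whether ethyl, methoxy or chlorine on this same carbon gives a step of similar size remains open. So does whether methyl on another aromatic carbon of the core does the same.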